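This account rests on a few compounds, and the source may have more. Where it says the series, first, only, none or still open, it means among the compounds named here.

Working notes on the shared core, in which only the substituent on the fused ring system and the link to the shared core vary.

Compound 1 `CC(C)[C@H](C[C@H]1OC(=O)NC1=O)c1ccc(-c2ccc3cccc(F)c3c2)[nH]c1=O` in an ADME assay on microsomes from liver (Rattus norvegicus) for metabolic stability (a lower number here means that the compound disappears faster, a higher number that the compound lasts longer), gives 0.95 h. Compound 2 `CCC(/C=C1\OC(=O)NC1=O)(CC)c1ccc(-c2ccc3cccc(F)c3c2)[nH]c1=O` in this assay gives > 3 h, which is a limit of the assay and not a number. Compound 3 `CCc1cccc2ccc(-c3ccc(C(/C=C4\OC(=O)NC4=O)(CC)CC)c(=O)[nH]3)cc12` in this assay gives 1.77 h. Of the two numbers shown, compound 3 stands highest, with compound 1 nearest at a gap within the scatter; the third value shown is a limit (the limit of > 3 h in this assay, at which 1 of the 3 values shown sits). Going by the values given here, the only measured step at the fused ring system is an at least 1.6-fold lower number from compound 2 to compound 3 (0.22 log units; that floor lies within the scatter), and its floor lies within the scatter, so it settles no direction on its own.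

Compound 4 `CCC(/C=C1\OC(=O)NC1=O)(CC)c1ccc(-c2ccc3cccc(C(F)(F)F)c3c2)[nH]c1=O` differs from compound 3 by trifluoromethyl in place of ethyl on an aromatic carbon. Among the compounds with values here, no measured step covers trifluoromethyl, and the one step at this position, an at least 1.6-fold lower number from compound 2 to compound 3 (0.22 log units; that floor lies within the scatter), concerns the ethyl against fluoro exchange only. The expected step is therefore a 1.2-fold higher number from compound 3 to compound 4 (0.09 log units; within the scatter), within the scatter, without a direction that the data can support. In this assay compound 4 is expected at 2.2 h, with a range from 1.1 h to 4 h, and the measurement will show whether the limit is reached again.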

Compound 4, half-life: 1.09 h
Compound 4: middle estimate off by 2.0-fold (0.30 log units), on the high side; measured number below the stated range.
By their numbers in this assay, from the lowest: compounds 1, 4 and 3 (each within the scatter of the next). At a limit, above all of these: compound 2.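

The change gives this position its first step beyond the scatter in this assay: trifluoromethyl in place of fluoro on the aromatic carbon brings an at least 2.7-fold lower number from compound 2 to compound 4 (0.43 log units; beyond the scatter), whereas the earlier step from fluoro to ethyl had only a floor within the scatter. Set against ethyl, trifluoromethyl gives a 1.6-fold lower number from compound 3 to compound 4 (0.21 log units; within the scatter), so these two groups are not separated at this position, and fluoro is set apart from trifluoromethyl but not yet from ethyl. The step from fluoro to trifluoromethyl still has only a floor and no full size, since compound 2 gives a limit of the assay and not a number: the limit of > 3 h in this assay, at which 1 of the 4 values shown sits.

From the compounds shown here alone, how far this difference extends to other groups at this position remains open, for instance whether a methoxy group, a nitrile or a chlorine atom would stay with fluoro or fall with ethyl and trifluoromethyl. Also open is whether the same exchange of fluoro for trifluoromethyl would give a step of like direction on the saturated link of compound 1, and the compounds shown give no cause for the step itself.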